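Removing a Fluorine and Cytotoxicity Across Two Cores

This account rests on a few compounds, and the source may have more. Where it says the series, first, only, none or still open, it means among the compounds named here.

Compound 1 `Fc1ccc(Nc2cc3[nH]c(Nc4ccc(N5CCN(CC6CC6)CC5)cn4)nc3cn2)cc1C(F)(F)F` and compound 2 `FC(F)(F)c1cccc(Nc2cc3[nH]c(Nc4ccc(N5CCN(CC6CC6)CC5)cn4)nc3cn2)c1` share one core, and in an ADME assay on CHO cells (Cricetulus griseus) for cytotoxicity, read by MTT assay (a higher number here means that more compound is tolerated, a lower number that less compound is tolerated), compound 1 gives 41000 nM while compound 2 gives 1700 nM. The change between them, (hydrogen in place of fluoro on an aromatic carbon), made a step of a 24-fold lower number from compound 1 to compound 2 (1.38 log units; beyond the scatter). Compound 3 `C[C@@H]1CN(C(=O)c2ccnc(Nc3nc4cnc(Nc5ccc(F)c(C(F)(F)F)c5)cc4[nH]3)c2)C[C@H](C)N1` carries the same 4-fluoro-3-(trifluoromethyl)phenyl group on another core; the difference between the two cores is not broken down here. In this assay compound 3 gives 29000 nM, a value within the scatter of compound 1 and well apart from compound 2. Compound 4 `C[C@@H]1CN(C(=O)c2ccnc(Nc3nc4cnc(Nc5cccc(C(F)(F)F)c5)cc4[nH]3)c2)C[C@H](C)N1` differs from compound 3 by hydrogen in place of fluoro on an aromatic carbon, the same change as that from compound 1 to compound 2, at a place described in the same words. For the measured compounds named here, because the step of a 24-fold lower number from compound 1 to compound 2 (1.38 log units; beyond the scatter) was large, compound 4 is expected to give a clearly lower number than compound 3, though only one such pair is known and the cores differ, so the size is estimated with caution. For compound 4 the expected step is a 12-fold lower number from compound 3 to compound 4 (1.06 log units; beyond the scatter). Compound 4 is therefore estimated at 2500 nM, between 700 nM and 9000 nM.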

Compound 4, half-maximal cytotoxic concentration in the CHO assay: 37000 nM
Beside the measured number, compound 4's estimate is 15-fold (1.17 log units) below it, outside the stated range (above it).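

On the core of compound 3, hydrogen in place of fluoro leaves the result in the CHO assay essentially unmoved, a 1.3-fold higher number from compound 3 to compound 4 (0.11 log units; within the scatter). In a physicochemical assay for solubility, read by HPLC, using the shake flask method, in phosphate buffer, measured as kinetic solubility, with a stated time of 20 h, at pH 6.5 (a lower number here means a less soluble compound, a higher number a more soluble compound), compound 3 gives 200000 nM and compound 4 gives 200000 nM. In the physicochemical assay the same pair thus shows no change at the digits printed from compound 3 to compound 4 (within the scatter). Set against the large step on the core of compound 1, the two results plainly differ: the same change on two cores in the CHO assay, a 24-fold lower number (1.38 log units; beyond the scatter) from compound 1 to compound 2 and a 1.3-fold higher number (0.11 log units; within the scatter) from compound 3 to compound 4, 31-fold (1.49 log units) apart, beyond the scatter of two such steps. For the compounds shown here, the change, made ortho to a trifluoromethyl group on both cores, therefore does not carry over in size from one core to the other, although with a single pair on each core this shows only that the two steps disagree, not which part of the cores goes with the difference.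

From the compounds shown here alone, it remains open whether a chloro or methoxy group in place of the fluoro would give steps that differ in the same way on these two cores. Going by these compounds alone, also open is whether the same change on a third core would resemble the step from compound 1 to compound 2 or the one from compound 3 to compound 4.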